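The source may report more compounds than this note shows. Statements on the series, on what has been measured and on what is new or still open speak of the compounds shown alone.

In a functional assay on SW-620 cells (Homo sapiens) for cytotoxicity, read by colorimetric assay (a higher number here means a weaker inhibitor, a lower number a stronger inhibitor), three compounds have been measured: compound 1 `O=C(/C=C/c1ccc(CN2C(=O)/C(=C3\Nc4ccccc4\C3=N/O)c3cccc(Cl)c32)cc1)NO` gives 60 nM, compound 2 `O=C(/C=C/c1ccc(CN2C(=O)/C(=C3\Nc4ccccc4\C3=N/O)c3cc(Cl)ccc32)cc1)NO` gives 80 nM and compound 3 `O=C(NO)c1ccc(CN2C(=O)/C(=C3\Nc4ccccc4\C3=N/O)c3cc(Cl)ccc32)cc1` gives 60 nM. Compound 2 lies within the usual scatter of both others, so it cannot be ranked against them. Compound 4 `COc1ccc2c(c1)/C(=C1/Nc3ccccc3/C1=N\O)C(=O)N2Cc1ccc(/C=C/C(=O)NO)cc1` changes compound 2 at one place: methoxy in place of chloro on an aromatic carbon. Among the measured compounds shown here, the only measured step, a 1.3-fold lower number from compound 2 to compound 3 (0.12 log units; within the scatter), concerns a different group, hydroxycarbamoyl in place of 2-(hydroxycarbamoyl)ethenyl, and stays within the scatter. No measurement tests the swap itself, so the range stays wide. The expected change is small, a 1.1-fold higher number from compound 2 to compound 4 (0.05 log units; within the scatter), with nothing beyond the scatter anticipated. For compound 4 the estimated value is 90 nM, within a range of 40 nM to 220 nM.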

Compound 4, half-maximal inhibitory concentration: 40 nM
Compound 4: middle estimate off by 2.3-fold (0.35 log units), on the high side; the measured number falls inside the stated range.
By their numbers in this assay, from the lowest: compounds 4, 1, 3 and 2 (each within the scatter of the next).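

In this assay, among the compounds shown here, methoxy in place of chloro on this aromatic carbon gives a 2.0-fold lower number from compound 2 to compound 4 (0.30 log units; within the scatter), the first reading of this swap at this place. The carbon therefore carries either group, one with two heavy atoms and a hydrogen-bond acceptor, the other with one heavy atom and none, without a step beyond the scatter. No other data here bear on this result. Still open, from the compounds shown here alone, is whether an amine, a carboxylic acid or a longer chain such as ethoxy on this carbon would stay within the scatter. Methoxy at the chloro site of compound 1 also remains open.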